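This account rests on a few compounds, and the source may have more. Where it says the series, first, only, none or still open, it means among the compounds named here.

Measured compounds:
- compound 1, `COc1ccccc1C1SCC(=O)N1CCN1CCCCC1`: 72%
- compound 2, `COc1cccc(C2SCC(=O)N2CCN2CCCCC2)c1`: 66%

Of the compounds shown here, two share a core and have been measured in an ADME assay on Vero cells (Chlorocebus sabaeus) for cytotoxicity, read by neutral red uptake, tested at 197 ug/mL; on this read-out higher numbers stand for a weaker effect at the one concentration tested and lower numbers for a stronger effect. In this assay compound 1 gives 72%, and compound 2 gives 66%. Compound 1 holds the higher of the two numbers, but its nearest neighbour, compound 2, lies only a few points lower, a gap that falls within the scatter of the method, so the two cannot be told apart.

Compound 3, `O=C1CSC(c2ccccc2Cl)N1CCN1CCCCC1`, has not yet been measured. It differs from compound 1 in one place: chloro in place of methoxy on an aromatic carbon. Among the measured compounds shown here, no pair of measured compounds differs in just this way, so there is no measured step that shows what this exchange does on its own. The two numbers that exist sit close together, and nothing among them points to a large move in either direction. The step of a number 7 percentage points lower from compound 1 to compound 3 (within the scatter) that the estimate implies is expected to stay within the scatter, with a slight lean toward a lower number. Compound 3 is therefore expected to give 65%, with a range from 45% to 85%.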

Compound 3, a percentage reported as activity, at one concentration (the size of the read-out at that concentration, not a potency): 71%
Compound 3: the middle estimate sits 6 percentage points below what was measured; low and high end bracket the measured number.
By their numbers in this assay, from the lowest: compounds 2, 3 and 1 (each within the scatter of the next).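

In this assay, among the compounds shown here, the exchange of methoxy for chloro on an aromatic carbon, ortho to a large group, gives a number 1 percentage points lower from compound 1 to compound 3 (within the scatter) and is the first single-place step available. At this position, a single chlorine can therefore stand in for the methoxy group, with its carbon and oxygen, without any change that this read-out can resolve, so the hydrogen-bond acceptor that leaves with the methoxy group is not required to keep the number within the scatter of compound 1. No measurement at hand explains why these two groups cannot be told apart here.

The compounds shown leave open whether any group at this position can move the number beyond the scatter, for instance an amine, a carboxylic acid or a longer alkoxy chain in place of the methoxy group or the chloro group. They also leave open whether chloro in place of methoxy would give a similarly small step on another carbon of the same aromatic ring, or at concentrations other than the single one tested.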